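Rearranging three fluorines: from compound 2 to compound 3

The compounds below may be only part of what the source reports. "The series", "measured", "known", "first", "only" and "open" are said of these compounds alone.

In an ADME assay on HEK293 cells (Homo sapiens) for cytotoxicity, with a stated time of 72 h (a lower number here means that less compound is needed, a higher number that more compound is needed for the effect), compound 1 (`C=C[C@@](C)(/C=C/c1ccc(Nc2ccc(OC)cc2)cc1)CCC=C(C)C`), which carries a 4-methoxyphenyl group on a nitrogen, gives > 36600 nM, and this is a limit of the assay, not a number. Compound 2 (`C=C[C@@](C)(/C=C/c1ccc(Nc2cc(F)c(F)cc2F)cc1)CCC=C(C)C`), with 2,4,5-trifluorophenyl in that place, gives > 36600 nM, and this too is only a limit. For the measured compounds named here, the one measured change is a step that the two limits leave unreadable from compound 1 to compound 2, so it offers no size to carry forward.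

Compound 3 (`C=C[C@@](C)(/C=C/c1ccc(Nc2cc(F)c(F)c(F)c2)cc1)CCC=C(C)C`) keeps the shared core and has the same atoms as compound 2, joined differently. The change is 3,4,5-trifluorophenyl in place of 2,4,5-trifluorophenyl on a nitrogen on an aromatic ring, with 3,4,5-trifluorophenyl in place of 2,4,5-trifluorophenyl on a nitrogen on an aromatic ring.

The only guide is that compound 1 and compound 2 behave alike here, as shown by the limit of > 36600 nM in this assay, at which 2 of the 2 values shown sit. No step beyond the usual scatter is therefore expected, and the estimated step is a step that the limit leaves unreadable from compound 2 to compound 3. The estimated value for compound 3 is 37000 nM, with an expected range from 16000 nM to 75000 nM.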

Compound 3, half-maximal effective concentration: > 36600 nM
Compound 3: no number, only a limit; the forecaster's own chance of this, stated with the estimate: 80%; the middle value is on the limit's open side.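

No step can be read among compound 1, compound 2 and compound 3, because all three values are limits of the assay and not numbers: the limit of > 36600 nM in this assay, at which 3 of the 3 values shown sit. From the compounds shown here alone, whether 4-methoxyphenyl, 2,4,5-trifluorophenyl and 3,4,5-trifluorophenyl on the nitrogen differ at all in this assay remains open, as does the size of any such difference.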